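Taking One Chloro Group Off Compound 3

This account rests on a few compounds, and the source may have more. Where it says the series, first, only, none or still open, it means among the compounds named here.

In a functional assay on IMR-32 cells (Homo sapiens) for cytotoxicity, read by sulforhodamine B assay, with a stated time of 48 h (on this read-out higher numbers stand for weaker inhibition and lower numbers for stronger inhibition), compound 1 (`O=C(c1cccnc1)c1cc(F)ccc1O`) gives 6210 nM while compound 2 (`O=C(c1cccnc1)c1ccccc1O`) gives 33700 nM and compound 3 (`O=C(c1cccnc1)c1cc(Cl)cc(Cl)c1O`) gives 28800 nM as its number. Compound 3 thus lies within the usual scatter of compound 2 and clearly higher than compound 1.

Compound 4 (`O=C(c1cccnc1)c1cc(Cl)ccc1O`) has not yet been measured. It differs from compound 3 by one change (hydrogen in place of chloro on an aromatic carbon) which is hydrogen in place of chloro on an aromatic carbon, ortho to a hydroxy group, and it keeps the other chloro group.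

Going by the values given here, only one measured step comes close to this change: a 5.4-fold higher number from compound 1 to compound 2 (0.73 log units; beyond the scatter) when hydrogen takes the place of fluoro. That step involves a different halogen and points to a higher number on losing one, so it is a loose guide. Compound 3, with two chloro groups, shows no clear difference from compound 2, which has none. Among the compounds with values here, compound 1 (6210 nM) has a single halogen, as compound 4 will, and has the lowest number so far. A modest move to a lower number therefore seems more likely than a rise.

The expected change is a 2.4-fold lower number from compound 3 to compound 4 (0.38 log units; beyond the scatter) in this assay as an estimate only. For compound 4 the estimated value is 12000 nM with an expected range from 4500 nM to 32000 nM on this read-out.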

Compound 4, half-maximal inhibitory concentration: 19500 nM
For compound 4 the middle estimate is 1.6-fold (0.21 log units) below the measured one; measured number inside the range.
By their numbers in this assay, from the lowest: compound 1; then compounds 4, 3 and 2 (each within the scatter of the next).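

In this assay, putting hydrogen in place of the chloro group ortho to a hydroxy group gives a 1.5-fold lower number from compound 3 to compound 4 (0.17 log units; within the scatter), so at this position chloro and hydrogen cannot be told apart on these numbers. Going by these compounds alone, the remaining chloro group shows a similar picture, with a 1.7-fold lower number from compound 2 to compound 4 (0.24 log units; within the scatter), whereas the halogen's identity does separate two compounds, with a 3.1-fold higher number from compound 1 to compound 4 (0.50 log units; beyond the scatter), which makes compound 1 the one compound that stands apart from the other three compounds. Nothing measured here explains why fluoro and chloro differ in this way, and no supporting data on the cause are available.

The compounds shown leave open whether a fluoro, methyl or methoxy group ortho to a hydroxy group would separate from hydrogen, as only chloro and hydrogen appear at that position. They also leave open whether the gap between compound 1 and compound 4 is special to fluoro, or whether a nitrile, a methyl group or an amine in the same place would also differ from chloro.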